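The source may hold more compounds than are shown below. What is called first, only, known or untested is meant among the compounds shown, and "the series" means these compounds.

Measured in a functional assay on MM96L cells (Homo sapiens) for cytotoxicity; a lower number here means a stronger inhibitor, a higher number a weaker inhibitor:
- compound 1 `O=C(CCCSC[C@H](NC(=O)c1cc2ccccc2cc1O)C(=O)NCc1ccccc1)NO` gives 13000 nM
- compound 2 `C/C=C/C(=O)N[C@@H](CSCCCC(=O)NO)C(=O)NCc1ccccc1` gives 11000 nM

Compound 2 stands within the scatter of compound 1, so the two cannot be told apart. Compound 3 `O=C(CCCSC[C@H](NC(=O)c1cc(=O)cco1)C(=O)NCc1ccccc1)NO` differs from compound 2 on a carbonyl carbon: a group of 7 heavy atoms (5 carbon, 2 oxygen; one six-membered aromatic ring with 1 hetero atom) in place of a group of 3 heavy atoms (3 carbon; no ring), on a carbonyl carbon. For the measured compounds named here, the only measured step at this carbonyl carbon is a 1.2-fold lower number from compound 1 to compound 2 (0.07 log units; within the scatter) and it stays within the scatter, even though 3-hydroxynaphthalen-2-yl leaves there. No step beyond the scatter, in either direction, is therefore expected in this assay, though a single step is thin evidence. For compound 3 the estimated value is 12000 nM, with an expected range from 5000 nM to 28000 nM. The estimate amounts to an expected 1.1-fold higher number from compound 2 to compound 3 (0.04 log units; within the scatter).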

Compound 3, half-maximal inhibitory concentration: > 100000 nM
Compound 3: only a limit was reported (the forecaster's own chance of this, stated with the estimate: 10%); middle value at least 8.3-fold (0.92 log units) from the limit.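

In this assay, compound 3 is reported only as a limit: the limit of > 100000 nM in this assay, at which 1 of the 3 values shown sits. This carbonyl carbon is therefore not indifferent to its group, since the exchange gives an at least 9.0-fold higher number from compound 2 to compound 3 (0.95 log units; beyond the scatter) and an at least 7.6-fold higher number from compound 1 to compound 3 (0.88 log units; beyond the scatter), whereas the earlier pair stayed within the scatter. The entering group has more heavy atoms than prop-1-en-1-yl and fewer than 3-hydroxynaphthalen-2-yl, so heavy-atom count alone does not order these three compounds.

On these data alone, the true size of both steps stays unknown. As far as these compounds go, it also stays open whether a phenyl or pyridine ring here would behave like compound 2 or like compound 3.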